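Shared-core series: acetyl to isopropyl at the chain carbon

The source may hold more compounds than are shown below. What is called first, only, known or untested is meant among the compounds shown, and "the series" means these compounds.

Of the compounds shown here, three of the shared core have been measured in an assay for inhibition of Fatty-acid amide hydrolase 1 (Rattus norvegicus); on this read-out lower numbers stand for stronger inhibition and higher numbers for weaker inhibition. Compound 1 `CC(=O)Cn1nnc(Cc2ccc(-c3ccccc3)cc2)n1` gives > 50000 nM there, which is a limit of the assay and not a number. Compound 2 `CN(C)C(=O)Cn1nnc(CNC(=O)c2ccc(-c3ccccc3)cc2)n1` likewise gives > 50000 nM, again a limit. Compound 3 `CC(=O)Cn1nnc(CNC(=O)c2ccc(-c3ccccc3)cc2)n1` gives > 50000 nM, also a limit of the assay. Among the compounds with values here, the only step between measured compounds that differ in one place, a step that the two limits leave unreadable from compound 2 to compound 3, carries no readable size, which rests on (the limit of > 50000 nM in this assay, at which 3 of the 3 values shown sit). Compound 3 thus sits at the same limit as the two others, and no ordering among the three can be read from the numbers shown.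

Compound 4 `CC(C)Cn1nnc(CNC(=O)c2ccc(-c3ccccc3)cc2)n1` differs from compound 3 by isopropyl in place of acetyl on a saturated chain carbon bound to an aromatic nitrogen. Within the data shown here, no measured step speaks to this particular change: the single step, methyl in place of dimethylamino on a carbonyl carbon, lies between two limits and has no size. With every value of the series at the limit, no step beyond the scatter can be expected in this assay for the change from compound 3 to compound 4, and the step is estimated as a step that the limit leaves unreadable from compound 3 to compound 4. Compound 4 is expected to give about 60000 nM in this assay, with a range from 15000 nM to 200000 nM, and most probably a limit will again be reported rather than a number.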

Compound 4, half-maximal inhibitory concentration: > 50000 nM
Compound 4: a limit, no number; the forecaster's own chance of this, stated with the estimate: 80%; the middle value does not contradict the limit.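

In this assay compound 4 gives > 50000 nM, a limit of the assay and not a number. Within the data shown here, no step from compound 2 or compound 3 to compound 4 can be read: the limit of > 50000 nM in this assay, at which 4 of the 4 values shown sit. The compounds shown leave open which change to the shared core, if any, would give a measurable value on this read-out.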